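The source may report more compounds than this note shows. Statements on the series, on what has been measured and on what is new or still open speak of the compounds shown alone.

Compound 1 `Cc1ccccc1N1CCN(C(=O)CN2C(=O)CC(C)C2=O)CC1` and compound 2 `CC1CC(=O)N(CC(=O)N2CCN(c3ccccc3Cl)CC2)C1=O` share one core and differ only in the group carried on the aromatic ring that hangs from the ring nitrogen. In a functional assay on the whole organism (strain CD1) with Mus musculus as the target, in the maximal electroshock model, with a stated time of 0.5 h (a lower number here means that less compound is needed, a higher number that more compound is needed for the effect), compound 1 gives 300 mg/kg, and in this assay compound 2 gives 300 mg/kg. Within the data shown here, the one recorded step, no change at the digits printed from compound 1 to compound 2 (within the scatter), leaves compound 2 level with compound 1 at the digits recorded, within the scatter. Compound 3 `CC1CC(=O)N(CC(=O)N2CCN(c3ccc(Cl)cc3)CC2)C1=O` departs from compound 2 in another way: 4-chlorophenyl in place of 2-chlorophenyl on an amine nitrogen in a ring. Among the measured compounds shown here, no measured pair covers a move of the chlorine to a different carbon of that aromatic ring. For the measured compounds named here, the only step available, from compound 1 to compound 2, concerns which group sits on the aromatic carbon and was itself without effect beyond the scatter. With nothing bearing directly on this change, the expectation for compound 3 in this assay is no step beyond the scatter, no change at the digits printed from compound 2 to compound 3 (within the scatter). Compound 3 is therefore estimated in this assay at 300 mg/kg, within a range from 150 mg/kg to 600 mg/kg.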

Compound 3, minimum effective dose: 100 mg/kg
Estimate against measurement, compound 3: 3.0-fold (0.48 log units) above; measured number below the stated range.
By their numbers in this assay, from the lowest: compound 3; then compounds 1 and 2 (each within the scatter of the next).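

In this assay, the place of the chlorine on the aromatic ring matters in a way the identity of the group did not in the earlier pair: exchanging chloro for methyl gave no change at the digits printed from compound 1 to compound 2 (within the scatter), whereas 4-chlorophenyl in place of 2-chlorophenyl, with the same atoms joined differently, gives a 3.0-fold lower number from compound 2 to compound 3 (0.48 log units; beyond the scatter). The 4-chlorophenyl group also separates from the 2-methylphenyl group, with a 3.0-fold lower number from compound 1 to compound 3 (0.48 log units; beyond the scatter), so compound 3 has the lowest number of the three, and its steps to both other compounds are beyond the scatter. Nothing available explains why the 4-chlorophenyl group gives the lower number.

The three compounds leave open whether this result belongs to chlorine alone or would also hold for a methyl, methoxy or trifluoromethyl group at the same place in a 4-substituted phenyl ring, and how a plain phenyl group would compare. They also cannot show whether the step from 2-chlorophenyl to 4-chlorophenyl would carry over to a core with an amine or a longer chain in place of the methyl group on the shared core.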